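Swapping 2-fluorophenyl for 3-methylphenyl on a shared core

This account rests on a few compounds, and the source may have more. Where it says the series, first, only, none or still open, it means among the compounds named here.

In a physicochemical assay for lipophilicity, read by HPLC, at pH 7.5 (on this read-out lower numbers stand for lower lipophilicity and higher numbers for higher lipophilicity), compound 1 (`CC[C@@H](Nc1c(C#N)c(-c2ccc(-c3ccccc3F)cc2)nc2cnccc12)C(N)=O`) gives 2.7 as the second highest of three measured numbers. Compound 2 (`N#Cc1c(-c2ccc(Br)cc2)nc2cnccc2c1NCC(N)=O`) reads lower at 1.9 and compound 3 (`CCOc1ccccc1-c1ccc(-c2nc3cncc(Cl)c3c(N[C@H](CC)C(N)=O)c2C#N)cc1`) reads higher at 3.7 with both gaps beyond the scatter. Going by the values given here, these two neighbours frame compound 1, but neither differs from it in one place only, and no measured pair does, so the data hold no direct precedent for the next change.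

That change leads to compound 4 (`CC[C@@H](Nc1c(C#N)c(-c2ccc(-c3cccc(C)c3)cc2)nc2cnccc12)C(N)=O`), which is still unmeasured. It carries 3-methylphenyl in place of 2-fluorophenyl on an aromatic carbon, para to a large group (3-methylphenyl in place of 2-fluorophenyl on an aromatic carbon). The expectation therefore rests on the structural change alone and remains tentative. In this assay the estimated step of a number 0.30 log units higher from compound 1 to compound 4 (within the scatter) is expected to be a small rise at about the edge of the usual scatter. For compound 4 the expected value is 3 with a range from 2.6 to 3.4 on this estimate.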

Compound 4, distribution coefficient: 3
For compound 4 middle estimate and measured number coincide at the digits printed; the measured number falls inside the stated range.
By their numbers in this assay, from the lowest: compound 2; then compounds 1 and 4 (each within the scatter of the next); then compound 3.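

Going by these compounds alone, this is the first comparison in the set that differs in one place only, and in this assay it reads a number 0.30 log units higher from compound 1 to compound 4 (within the scatter). At this aromatic carbon, para to a large group, exchanging 2-fluorophenyl for 3-methylphenyl, each with 7 heavy atoms and one six-membered aromatic ring of carbon only, therefore gives two compounds that this read-out does not separate. No further measurement bears on why the two compounds read as they do.

On these data alone, whether a group of another kind at this place, such as an amine, a carboxylic acid or a longer chain, would move the number beyond the scatter remains open. Also open, as far as these compounds go, is whether the same exchange would read alike on a different core, such as that of compound 3.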